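The compounds below may be only part of what the source reports. "The series", "measured", "known", "first", "only" and "open" are said of these compounds alone.

Of the compounds shown here, three that share one core have so far been tested in an ADME assay on MT4 cells (Homo sapiens) for cytotoxicity, read by MTT assay; on this read-out higher numbers stand for lower toxicity in this test and lower numbers for higher toxicity in this test. In this test, compound 1 (`Cc1ccc(N(C(=O)c2cccc([N+](=O)[O-])c2)C(=S)OCCN2C(=O)c3ccccc3C2=O)cc1`) gives 100000 nM, compound 2 (`O=C1c2ccccc2C(=O)N1CCOC(=S)N(C(=O)c1ccc(Cl)c([N+](=O)[O-])c1)c1ccccc1`) gives 51000 nM and compound 3 (`O=C1c2ccccc2C(=O)N1CCOC(=S)N(C(=O)c1c(F)cccc1F)c1ccc(Cl)cc1`) gives 39000 nM. Compound 3 lies within the usual scatter of compound 2, so these two cannot be ranked against each other. Compound 1 has a higher number than compound 3, and that gap lies beyond the scatter.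

The next molecule, compound 4 (`COc1cccc(OC)c1C(=O)N(C(=S)OCCN1C(=O)c2ccccc2C1=O)c1ccc(Cl)cc1`), differs from compound 3 in one place: 2,6-dimethoxyphenyl stands in place of 2,6-difluorophenyl on a carbonyl carbon. The counted difference reads (2,6-dimethoxyphenyl in place of 2,6-difluorophenyl on a carbonyl carbon).

For the measured compounds named here, no two measured compounds differ in only one place, so the data do not show directly what a single swap does in this assay. Going by the values given here, the only guide is the modest spread of the three values, from compound 3 at 39000 nM to compound 1 at 100000 nM. A small upward move that stays within the scatter is therefore expected, and the estimated change is a 1.3-fold higher number from compound 3 to compound 4 (0.11 log units; within the scatter). The expected value for compound 4 is 50000 nM, with an estimated range from 20000 nM to 100000 nM.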

Compound 4, half-maximal cytotoxic concentration: 69000 nM
The estimate for compound 4 lay 1.4-fold (0.14 log units) below the measured number; the measured number falls inside the stated range.
By their numbers in this assay, from the lowest: compounds 3, 2, 4 and 1 (each within the scatter of the next, the first and the last beyond it).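

For the compounds shown here, this is the first pair of compounds that differ in only one place, so this assay can now be read for a single swap: 2,6-dimethoxyphenyl in place of 2,6-difluorophenyl on a carbonyl carbon gives a 1.8-fold higher number from compound 3 to compound 4 (0.25 log units; within the scatter) and so does not separate the two compounds. The entering group carries hydrogen-bond acceptors and the leaving group carries none, yet this exchange on the carbonyl carbon produces no difference that can be told apart from the ordinary spread of repeated measurements in this test. Nothing in the data presented explains this result.

On these data alone, whether a plain phenyl, an amine or a carboxylic acid on the aromatic ring, or a longer chain in place of that ring, would shift the number beyond the scatter remains open. Going by these compounds alone, it is also open whether the same exchange would read the same way with a different group on the amide-type nitrogen, since this single pair tests it with only one such group.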